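The source may report more compounds than this note shows. Statements on the series, on what has been measured and on what is new or still open speak of the compounds shown alone.

Measured so far in a functional assay on HCT-15 cells (Homo sapiens); a lower number here means that less compound is needed, a higher number that more compound is needed for the effect:
- Compound 1 `CCOC(=O)C(=O)N1N=C(c2ccc(N(C)C)cc2)OC1c1cc(OC)c(OC)c(OC)c1`: 45 uM
- Compound 2 `COc1cc(C2OC(c3ccc(N(C)C)cc3)=NN2C(=O)COC(C)=O)cc(OC)c1OC`: 0.019 uM
- Compound 3 `COc1cc(C2OC(c3ccc(N(C)C)cc3)=NN2C(=O)CN(C)C)cc(OC)c1OC`: 80 uM

Compound 3 gives 80 uM, at the high end of the three. The measured steps to it are a 1.8-fold higher number from compound 1 to compound 3 (0.25 log units; within the scatter) and a 4200-fold higher number from compound 2 to compound 3 (3.62 log units; beyond the scatter).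

Compound 4 `COc1cc(C2OC(c3ccc(N(C)C)cc3)=NN2C(=O)CNC=O)cc(OC)c1OC` differs by formylamino in place of dimethylamino on a saturated chain carbon bound to a carbonyl carbon. Going by the values given here, no measured step makes this exact swap. The closest is the exchange of acetoxy for dimethylamino, a 4200-fold higher number from compound 2 to compound 3 (3.62 log units; beyond the scatter). Acetoxy and formylamino both contain a carbonyl, but so does the ethoxycarbonyl of compound 1, which gives 45 uM, so only part of that large step is expected to carry over in this assay. The expected change is a 27-fold lower number from compound 3 to compound 4 (1.43 log units; beyond the scatter), towards a lower number. For compound 4 the estimated value is 3 uM, with an expected range of 0.1 uM to 80 uM.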

Compound 4, concentration for half-maximal effect: 0.035 uM
Beside the measured number, compound 4's estimate is 86-fold (1.93 log units) above it; measured number below the stated range.
By their numbers in this assay, from the lowest: compounds 2 and 4 (each within the scatter of the next); then compounds 1 and 3 (each within the scatter of the next).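

In this assay, formylamino on this saturated chain carbon bound to a carbonyl carbon recovers nearly all that dimethylamino loses (a 2300-fold lower number from compound 3 to compound 4 (3.36 log units; beyond the scatter)). Against acetoxy the change stays within the usual scatter (a 1.8-fold higher number from compound 2 to compound 4 (0.27 log units; within the scatter)), so the low number does not depend on acetoxy alone. Ethoxycarbonyl on the carbonyl carbon does not share it, even though it also holds a carbonyl (a 1300-fold lower number from compound 1 to compound 4 (3.11 log units; beyond the scatter)).

From the compounds shown here alone, whether a primary amine, acetylamino or a longer chain here would keep the low number stays open. Nothing measured here explains these gaps.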